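Methoxy added to the central ring of a urea inhibitor

This account rests on a few compounds, and the source may have more. Where it says the series, first, only, none or still open, it means among the compounds named here.

Measured compounds:
compound 1 `COc1cccc(NC(=O)Nc2ccc(Nc3ncnc4c3OCCN4)cc2)c1`, 5290 nM
compound 2 `CC(C)(C)c1cc(NC(=O)Nc2ccc(Nc3ncnc4c3OCCN4)cc2)no1`, 34 nM
compound 3 `CC(C)(C)c1csc(NC(=O)Nc2ccc(Nc3ncnc4c3OCCN4)cc2)n1`, 5170 nM

In an assay on isolated protein for inhibition of proto-oncogene tyrosine-protein kinase receptor Ret variant V804M (Homo sapiens), read by 33P incorporation, with stated times of 15 min and 40 min (on this read-out higher numbers stand for weaker inhibition and lower numbers for stronger inhibition), compound 2 gives the lowest of the three numbers. Its nearest neighbour is compound 3, reached by a 150-fold higher number from compound 2 to compound 3 (2.18 log units; beyond the scatter); the step of a 160-fold lower number from compound 1 to compound 2 (2.19 log units; beyond the scatter) is of similar size. Compound 4 `COc1cc(NC(=O)Nc2cc(C(C)(C)C)on2)ccc1Nc1ncnc2c1OCCN2` keeps the urea partner of compound 2 and differs only by methoxy in place of hydrogen on an aromatic carbon, ortho to a large group and meta to a large group. Within the data shown here, none of the measured steps touches this ring: both a 160-fold lower number from compound 1 to compound 2 (2.19 log units; beyond the scatter) and a 1.0-fold lower number from compound 1 to compound 3 (0.01 log units; within the scatter) change the group on the other amide-type nitrogen. Among the measured compounds shown here, the account therefore rests on no comparable step, and for this assay the change is expected to stay within the scatter, with a 1.5-fold higher number from compound 2 to compound 4 (0.17 log units; within the scatter). Compound 4 is estimated at 50 nM, with a range from 15 nM to 200 nM.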

Compound 4, half-maximal inhibitory concentration: 33 nM
Compound 4: the middle estimate sits 1.5-fold (0.18 log units) above what was measured; the range from low to high includes it.
By their numbers in this assay, from the lowest: compounds 4 and 2 (each within the scatter of the next); then compounds 3 and 1 (each within the scatter of the next).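

In this assay, methoxy in place of hydrogen on this aromatic carbon, ortho to a large group and meta to a large group, leaves the number within the scatter (a 1.0-fold lower number from compound 2 to compound 4 (0.01 log units; within the scatter)). Among these compounds, the earlier steps all changed the group on the other amide-type nitrogen, so this is the only measured change on the six-membered aromatic ring, and with 5-(tert-butyl)-1,2-oxazol-3-yl as the partner that ring carbon carries methoxy with no change beyond the scatter. Nothing in the information available accounts for this result.

From the compounds shown here alone, whether methoxy has the same outcome with 3-methoxyphenyl or 4-(tert-butyl)-1,3-thiazol-2-yl as the partner remains open. Also open, going by these compounds, is whether an amine, a carboxylic acid or a longer alkoxy chain at this place would leave the number equally unchanged.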